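Trading a Decyl Chain for a Carbamoyl Arm

The source may hold more compounds than are shown below. What is called first, only, known or untested is meant among the compounds shown, and "the series" means these compounds.

Within the data shown here, compound 1 `CCCCCCCCCCn1cc(Cn2nc(N)c3c(C(F)(F)F)cc(-c4ccccc4)nc32)nn1` gives 48.7 ug/mL in a functional assay on THP-1 cells (Homo sapiens) for cytotoxicity, read by MTT assay, with a stated time of 24 h (a higher number here means a weaker inhibitor, a lower number a stronger inhibitor), the lower of the two numbers measured so far. Among the measured compounds shown here, compound 2 `Cc1ccc(-n2cc(Cn3nc(N)c4c(C(F)(F)F)cc(-c5ccccc5)nc43)nn2)cc1` gives 98.6 ug/mL in this assay, and the one step between them, a 2.0-fold higher number from compound 1 to compound 2 (0.31 log units; beyond the scatter), shows what putting 4-methylphenyl in place of decyl did. Compound 3 `Cc1ccc(NC(=O)Cn2cc(Cn3nc(N)c4c(C(F)(F)F)cc(-c5ccccc5)nc43)nn2)cc1` differs from compound 1 thus: (4-methylphenyl)carbamoyl in place of nonyl on a saturated chain carbon bound to an aromatic nitrogen. For the measured compounds named here, since this change likewise takes away nonyl and brings in a 4-methylphenyl ring, the step from compound 1 to compound 2 is the only guide, and a modest rise of similar size is expected, a 1.6-fold higher number from compound 1 to compound 3 (0.22 log units; within the scatter). Compound 3 is therefore estimated at 80 ug/mL, within 40 ug/mL to 160 ug/mL.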

Compound 3, half-maximal inhibitory concentration: 41.5 ug/mL
Compound 3: middle estimate off by 1.9-fold (0.29 log units), on the high side; low and high end bracket the measured number.
By their numbers in this assay, from the lowest: compounds 3 and 1 (each within the scatter of the next); then compound 2.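

In this assay, the ((4-methylphenyl)carbamoyl)methyl arm cannot be told apart from the decyl chain (a 1.2-fold lower number from compound 1 to compound 3 (0.07 log units; within the scatter)), so the 4-methylphenyl ring in this arm does not carry the rise seen with compound 2. Moving from the ring set directly on the aromatic nitrogen to the same ring held out on the carbamoyl arm gives a 2.4-fold lower number from compound 2 to compound 3 (0.38 log units; beyond the scatter). Nothing here explains why these compounds differ. The compounds shown leave open whether the amide itself matters or only the spacing of the ring, which a benzyl group or a carboxylic acid at this place could help separate.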